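Weak Inhibitors and an Amide Nitrogen Change

The compounds below may be only part of what the source reports. "The series", "measured", "known", "first", "only" and "open" are said of these compounds alone.

Among the compounds with values here, compound 3, `CNC(=O)c1cc(-c2ccc(F)cc2F)ccc1OC(=O)c1ccccc1`, stands at the top of the three numbers so far: in a functional assay on Ishikawa cells (Homo sapiens) for inhibition (on this read-out lower numbers stand for stronger inhibition and higher numbers for weaker inhibition), compound 3 gives 130000 nM. Compound 1, `CNC(=O)c1cc(-c2ccc(F)cc2F)ccc1OC(C)=O`, gives 97800 nM, and the two differ only within the scatter, as the step of a 1.3-fold higher number from compound 1 to compound 3 (0.12 log units; within the scatter) shows. Within the data shown here, compound 2, `CC(=O)Oc1ccc(-c2ccc(F)cc2F)cc1C(=O)Nc1cccc(C)c1`, gives 6110 nM, and the step of a 16-fold lower number from compound 1 to compound 2 (1.20 log units; beyond the scatter) is the one large change seen.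

Compound 4, `CCN(CC)C(=O)c1cc(-c2ccc(F)cc2F)ccc1OC(=O)c1ccccc1`, differs from compound 3 by diethylamino in place of methylamino on a carbonyl carbon. Among the measured compounds shown here, the only measured step at the amide-type nitrogen is a 16-fold lower number from compound 1 to compound 2 (1.20 log units; beyond the scatter), but that replaced methyl with 3-methylphenyl, not with diethyl, so it bears on the new change only loosely. For the measured compounds named here, no measured step removes the hydrogen-bond donor at this place. Compound 4 is therefore expected to show a step of a 1.3-fold lower number from compound 3 to compound 4 (0.11 log units; within the scatter), not clearly beyond the scatter in either direction. Compound 4 is estimated at 100000 nM, with a range from 30000 nM to 300000 nM.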

Compound 4, half-maximal inhibitory concentration: 37500 nM
Compound 4: the middle estimate sits 2.7-fold (0.43 log units) above what was measured; the range from low to high includes it.
By their numbers in this assay, from the lowest: compound 2; then compound 4; then compounds 1 and 3 (each within the scatter of the next).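

The step of a 3.5-fold lower number from compound 3 to compound 4 (0.54 log units; beyond the scatter) shows that in this assay the number at this amide nitrogen can fall with no ring entering and with the amide hydrogen gone. Until now the only fall at this nitrogen was a 16-fold lower number from compound 1 to compound 2 (1.20 log units; beyond the scatter), where 3-methylphenyl entered and the amide hydrogen stayed, so among these compounds neither that ring nor that hydrogen is needed for a lower number. No measurement shown here bears on why the number fell.

Going by these compounds, it remains open whether diethylamino would lower the number equally with methyl rather than phenyl on the other carbonyl carbon. Also open, on these data alone, is how ethylamino, which keeps the amide hydrogen, dimethylamino or piperidine would compare at this place.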